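Extending a Sulfonyl Chain on a Weak Aortic Inhibitor

This account rests on a few compounds, and the source may have more. Where it says the series, first, only, none or still open, it means among the compounds named here.

Compound 1, `CCCc1cnc(-c2nn(Cc3ccccc3F)c3ncccc23)nc1N`, gives 252000 nM in a functional assay (aorta) with Oryctolagus cuniculus as the target; a lower number here means a stronger inhibitor, a higher number a weaker inhibitor.
Compound 2, `CCCCCc1cnc(-c2nn(Cc3ccccc3F)c3ncccc23)nc1N`, gives 200000 nM in this assay.
Compound 3, `CS(=O)(=O)c1cnc(-c2nn(Cc3ccccc3F)c3ncccc23)nc1N`, gives 261000 nM in this assay.

Compound 4, `CCCS(=O)(=O)c1cnc(-c2nn(Cc3ccccc3F)c3ncccc23)nc1N`, is not yet measured. It arises from compound 3 by ethyl in place of hydrogen on a saturated chain carbon bound to a sulfonyl sulfur. The same kind of change has been made once already: ethyl in place of hydrogen on a saturated chain carbon, three bonds along the chain from an aromatic carbon, which gave a 1.3-fold lower number from compound 1 to compound 2 (0.10 log units; within the scatter). The surroundings differ, though: in the earlier pair the carbon sits three bonds along the chain from an aromatic carbon, whereas in compound 3 it is bound to a sulfonyl sulfur. The two cores differ by methylsulfonyl in place of propyl on an aromatic carbon, a change that gave a 1.0-fold higher number from compound 1 to compound 3 (0.02 log units; within the scatter). All three measured numbers lie within the scatter of one another. Because of a 1.3-fold lower number from compound 1 to compound 2 (0.10 log units; within the scatter), the expected step is a 1.1-fold lower number from compound 3 to compound 4 (0.05 log units; within the scatter). Compound 4 is thus expected to give 230000 nM, between 120000 nM and 450000 nM.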

Compound 4, half-maximal inhibitory concentration: 378000 nM
The estimate for compound 4 lay 1.6-fold (0.22 log units) below the measured number; the range from low to high includes it.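

In this assay ethyl in place of hydrogen gives two steps on two cores that cannot be told apart: the same change on two cores in this assay, a 1.3-fold lower number (0.10 log units; within the scatter) from compound 1 to compound 2 and a 1.4-fold higher number (0.16 log units; within the scatter) from compound 3 to compound 4, 1.8-fold (0.26 log units) apart, within the scatter of two such steps.

The new step reads a 1.4-fold higher number from compound 3 to compound 4 (0.16 log units; within the scatter) and propylsulfonyl in place of the simple chains gives a 1.5-fold higher number from compound 1 to compound 4 (0.18 log units; within the scatter) and a 1.9-fold higher number from compound 2 to compound 4 (0.28 log units; within the scatter) with no difference that stands out from the scatter.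

The change therefore carries between these two cores without a detectable difference, yet this does not show that its effect is the same on both, as every step here is too small to tell.

Still open, from the compounds shown here alone, is whether any group on that aromatic carbon moves the number beyond the scatter. An amine or a carboxylic acid in place of propylsulfonyl would be one such question.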